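Replacing a methylcarbamoyl group with an ethenyl ester

The source may report more compounds than this note shows. Statements on the series, on what has been measured and on what is new or still open speak of the compounds shown alone.

Compound 1, `CCOC(=O)c1ccc(-c2nn(CC)c3ccccc23)cc1`: in a functional assay on cells (Platelet, Homo sapiens) for inhibition (on this read-out lower numbers stand for stronger inhibition and higher numbers for weaker inhibition), compound 1 gives > 10000 nM, a limit of the assay and not a number.
Compound 2, `CCCCn1nc(-c2ccc(C(=O)OCC)cc2)c2ccccc21`: in this assay compound 2 gives > 10000 nM, again a limit.
Compound 3, `CNC(=O)c1ccc(-c2nn(Cc3ccccc3)c3ccccc23)cc1`: in this assay compound 3 gives > 10000 nM, also a limit.

Compound 3 therefore stands at the limit of > 10000 nM in this assay, at which 3 of the 3 values shown sit, so nothing places it above or below its two companions. For the measured compounds named here, the only measured single-point step, a step that the two limits leave unreadable from compound 1 to compound 2, concerns a substituent on the chain at the aromatic nitrogen and says nothing readable about the opposite end of the molecule.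

The next compound, compound 4, `CCOC(=O)/C=C/c1ccc(-c2nn(Cc3ccccc3)c3ccccc23)cc1`, differs from compound 3 by 2-(ethoxycarbonyl)ethenyl in place of methylcarbamoyl on an aromatic carbon. Going by the values given here, no measured step bears on this exchange, and every value so far sits at a limit, so there is no anchor for a shift in either direction. Compound 4 is expected to give about 10000 nM in this assay, with a range from 3000 nM to 30000 nM. The expected step of a number no higher from compound 3 to compound 4 (the limit leaves the size open) is thus none beyond the scatter, most likely a further limit.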

Compound 4, half-maximal inhibitory concentration: > 10000 nM
Compound 4: no number, only a limit (the forecaster's own chance of this, stated with the estimate: 75%); the middle value lies on the limit itself.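

Compound 3 and compound 4 both give only a limit in this assay, so the exchange between them cannot be read as a step in either direction: the limit of > 10000 nM in this assay, at which 4 of the 4 values shown sit.

The compounds shown leave open which change to the shared core or its groups, if any, would give an actual number in this assay.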